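The source may report more compounds than this note shows. Statements on the series, on what has been measured and on what is new or still open speak of the compounds shown alone.

Of the compounds shown here, three built on one shared core have been measured so far: compound 1 `Cc1nc(N)sc1CCCN/C(N)=N/C(=S)NC(c1ccccc1)c1ccccc1`, compound 2 `Cc1nc(N)sc1CCCN/C(N)=N/C(=O)NC(c1ccccc1)C(C)C` and compound 3 `CCCCCCNC(=O)/N=C(\N)NCCCc1sc(N)nc1C`. In a functional assay on Right cardiac atrium for agonist activity at histamine H2 receptor (Cavia porcellus), with a stated time of 30 min, in the presence of a further agent that is not named here (a lower number here means that less compound is needed, a higher number that more compound is needed for the effect), compound 1 gives 66.1 nM, compound 2 gives 34.7 nM and compound 3 gives 15.9 nM. Compound 3 therefore stands lowest of the three numbers, and both of the others lie above it by more than the usual scatter, compound 2 being the nearer and compound 1 the further.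

The next step leads from compound 3 to compound 4 `Cc1nc(N)sc1CCCN/C(N)=N/C(=O)NC(C)c1ccco1`. The change is confined to one place: 1-(furan-2-yl)ethyl in place of hexyl on an amide-type nitrogen. In plain terms a straight chain on the amide-type nitrogen is exchanged for a shorter branched group carrying a ring.

Going by the values given here, no pair of measured compounds differs in just this way, so the size of the step has to be judged from what the three numbers show. Compound 2, which also carries a branched group with a ring on that nitrogen, gives 34.7 nM, a higher number than compound 3. The expected step of a 1.9-fold higher number from compound 3 to compound 4 (0.28 log units; within the scatter) is therefore a modest rise in the number, near the edge of the scatter. Compound 4 is expected to give 30 nM, within a range from 12 nM to 90 nM.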

Compound 4, half-maximal effective concentration: 9.77 nM
Compound 4: middle estimate off by 3.1-fold (0.49 log units), on the high side, and the stated range ends above it.
By their numbers in this assay, from the lowest: compounds 4 and 3 (each within the scatter of the next); then compounds 2 and 1 (each within the scatter of the next).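

In this assay the step of a 1.6-fold lower number from compound 3 to compound 4 (0.21 log units; within the scatter) stays within the usual scatter, so these two compounds cannot be told apart in this test. Going by these compounds alone, they form the first measured pair that differs in one place only, and they show that the amide-type nitrogen can carry either hexyl, a straight chain with no ring, or 1-(furan-2-yl)ethyl, a branched group with a five-membered aromatic ring and a hydrogen-bond acceptor, with no readable change in the number. Nothing measured here explains why two groups so different in shape give numbers this close, so the result stands as an observation without a known cause.

From the compounds shown here alone, it remains open whether the furan ring, its oxygen or the branch matters on its own, which a pair such as 1-phenylethyl, with a phenyl ring in place of the furan, and furan-2-ylmethyl, without the branching methyl, could begin to separate. Going by these compounds, it is also open how far this tolerance at the nitrogen extends, for instance to a longer chain such as decyl or to a group bearing a carboxylic acid.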